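The source may report more compounds than this note shows. Statements on the series, on what has been measured and on what is new or still open speak of the compounds shown alone.

Compound 2, `Cn1c(Cc2nn(CCC(=O)O)c(=O)c3ccccc23)nnc1SCC(=O)Nc1ccc(Cl)cc1Cl`, carries a carboxy group on the chain attached to its core. In an assay on NK92 cells for inhibition of interleukin-15 (Homo sapiens), read by AlphaScreen, with stated times of 30 min and 1 h (a higher number here means a weaker inhibitor, a lower number a stronger inhibitor), compound 2 gives only a limit, > 30000 nM. Compound 1, `Cn1c(Cc2nn(CCC=O)c(=O)c3ccccc23)nnc1SCC(=O)Nc1ccc(Cl)cc1Cl`, differs from it in one place, and in this assay compound 1 gives 20000 nM. For the measured compounds named here, the step of an at least 1.5-fold higher number from compound 1 to compound 2 (0.17 log units; that floor lies within the scatter) is the only measured step here, and it ends at the limit of > 30000 nM in this assay, at which 1 of the 2 values shown sits. Compound 3, `CN(C)CCCn1nc(Cc2nnc(SCC(=O)Nc3ccc(Cl)cc3Cl)n2C)c2ccccc2c1=O`, carries the change ((dimethylamino)methyl in place of carboxy on a saturated chain carbon, two bonds along the chain from an aromatic nitrogen). Going by the values given here, no measured step covers that change, so the expectation rests on little. For compound 3 the expected step is an at least 2.0-fold lower number from compound 2 to compound 3 (0.30 log units; that floor lies within the scatter), with wide uncertainty. Compound 3 is estimated at 15000 nM, between 4000 nM and 60000 nM.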

Compound 3, half-maximal inhibitory concentration: > 30000 nM
Compound 3: a limit, no number; the forecaster's own chance of this, stated with the estimate: 35%; middle value at least 2.0-fold (0.30 log units) away from the limit.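

In this assay compound 3 also gives only a limit, so the step between compound 2 and compound 3 cannot be read. Against the formyl group of compound 1, the change reads as an at least 1.5-fold higher number from compound 1 to compound 3 (0.17 log units; that floor lies within the scatter), so it shows no loss beyond the scatter. At this position, a chain ending in a carboxy group and one ending in a dimethylamino group both give no exact number: the limit of > 30000 nM in this assay, at which 2 of the 3 values shown sit.

Going by these compounds, whether a chain ending in a hydroxy group or a primary amide, or a shorter chain, would give a number under this limit stays open.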